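Trimethoxyphenyl ketone on the thienyl-bearing core

The source may report more compounds than this note shows. Statements on the series, on what has been measured and on what is new or still open speak of the compounds shown alone.

Among the measured compounds shown here, compound 3 `COc1cc(-c2nnc3n2NC(c2cccs2)C(C(=O)c2ccc(F)cc2)S3)cc(OC)c1OC` stands second highest of the three numbers so far in a functional assay on A549 cells (Homo sapiens) for cytotoxicity, read by MTT assay, with a stated time of 48 h; on this read-out lower numbers stand for stronger inhibition and higher numbers for weaker inhibition: compound 3 gives 45000 nM. Its nearest neighbour is compound 1 `COc1cc(C(=O)C2Sc3nnc(-c4cc(OC)c(OC)c(OC)c4)n3NC2c2ccco2)cc(OC)c1OC`, which gives 48300 nM, a number within the scatter of compound 3. The furthest is compound 2 `COc1cc(-c2nnc3n2NC(c2cccs2)C(C(=O)c2ccc(C)cc2)S3)cc(OC)c1OC`, which gives 12700 nM; the single-change step a 3.5-fold higher number from compound 2 to compound 3 (0.55 log units; beyond the scatter) is the only one measured in this assay.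

Compound 4 `COc1cc(C(=O)C2Sc3nnc(-c4cc(OC)c(OC)c(OC)c4)n3NC2c2cccs2)cc(OC)c1OC` differs from compound 3 by 3,4,5-trimethoxyphenyl in place of 4-fluorophenyl on a carbonyl carbon. The step from compound 2 to compound 3 also alters the aryl group on the carbonyl carbon, but it exchanges different groups, so it only sets a rough scale for what a change at this place can do. For the measured compounds named here, compound 4 shares the 3,4,5-trimethoxyphenyl ketone with compound 1, whose value in this assay is 48300 nM and whose core differs from compound 4 at another place, so no single-change step connects them. The two trimethoxyphenyl-ketone and fluorophenyl-ketone values already seen lie within the scatter of each other.

Compound 4 is therefore expected to give about 45000 nM in this assay, in the range 20000 nM to 100000 nM. The expected step of no change at the digits printed from compound 3 to compound 4 (within the scatter) is estimated to stay within the scatter.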

Compound 4, half-maximal inhibitory concentration: > 100000 nM
Compound 4: a limit, no number; the forecaster's own chance of this, stated with the estimate: 10%; middle value at least 2.2-fold (0.34 log units) from the limit.
By their numbers in this assay, from the lowest: compound 2; then compounds 3 and 1 (each within the scatter of the next). At a limit, above all of these: compound 4.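

In this assay compound 4 reads as a limit and not as a number: > 100000 nM. On the carbonyl carbon, an at least 2.2-fold higher number from compound 3 to compound 4 (0.34 log units; beyond the scatter) and an at least 7.8-fold higher number from compound 2 to compound 4 (0.89 log units; beyond the scatter) are both beyond the scatter, so this place spans more than the single earlier step, a 3.5-fold higher number from compound 2 to compound 3 (0.55 log units; beyond the scatter), had shown, with 3,4,5-trimethoxyphenyl at the weak end of the aryl groups compared here. The saturated ring carbon also counts, a place no earlier single-change step had touched: with the 3,4,5-trimethoxyphenyl ketone held, an at least 2.0-fold higher number from compound 1 to compound 4 (0.31 log units; beyond the scatter), and all three new steps are bounded from one side only, so their true sizes are unknown: the limit of > 100000 nM in this assay, at which 1 of the 4 values shown sits.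

Still open, from the compounds shown here alone, is how far the exchange of thiophen-2-yl and furan-2-yl carries over to a ketone with 4-fluorophenyl or 4-methylphenyl, since this step has been read with 3,4,5-trimethoxyphenyl alone. Also open, going by these compounds, is how the carbonyl carbon would respond to an aryl group bearing an amine or a carboxylic acid, or to a single methoxy group in place of the three, and whether any such group would bring the number below that of compound 2, 12700 nM.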